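A Methyl Group on the Five-Membered Ring of Compound 2

The compounds below may be only part of what the source reports. "The series", "measured", "known", "first", "only" and "open" are said of these compounds alone.

For the measured compounds named here, compound 2 `O=C(O)CCCC/C=C(\c1cccnc1)c1cccs1` gives 20 nM in an assay (Equus caballus) for inhibition of Thromboxane-A synthase (Homo sapiens), using microsomes (a lower number here means a stronger inhibitor, a higher number a weaker inhibitor), the lowest of the three numbers measured so far. Compound 1 `O=C(O)C(CCC/C=C(\c1cccnc1)c1cccs1)c1ccccc1` gives 50 nM, and the step of a 2.5-fold lower number from compound 1 to compound 2 (0.40 log units; beyond the scatter) is modest but beyond the scatter. Compound 3 `O=C(O)CCCC/C=C(/c1cccnc1)c1cccs1` gives 54 nM; the step of a 2.7-fold higher number from compound 2 to compound 3 (0.43 log units; beyond the scatter) is likewise modest, and it rests on (the fact that compounds 2 and 3 differ only in the configuration as drawn).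

Compound 4 `Cc1ccsc1/C(=C/CCCCC(=O)O)c1cccnc1` differs from compound 2 in one place: methyl in place of hydrogen on an aromatic carbon. Neither measured step bears directly on this change. Going by the values given here, the step from compound 1 to compound 2 concerns the chain bound to the carbonyl carbon, and the step from compound 2 to compound 3 concerns only the configuration of the double bond; no measured pair varies the five-membered aromatic ring with 1 sulfur. The two measured steps were both modest, so a change of similar or smaller size is expected here, in either direction or none beyond the scatter. The step of a 1.3-fold higher number from compound 2 to compound 4 (0.10 log units; within the scatter) is therefore expected to stay small. Compound 4 is estimated to give 25 nM, within a range from 8 nM to 80 nM.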

Compound 4, half-maximal inhibitory concentration: 29 nM
The estimate for compound 4 lay 1.2-fold (0.06 log units) below the measured number; the measured number falls inside the stated range.
By their numbers in this assay, from the lowest: compounds 2, 4, 1 and 3 (each within the scatter of the next, the first and the last beyond it).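

Methyl in place of hydrogen on an aromatic carbon gives a 1.5-fold higher number from compound 2 to compound 4 (0.16 log units; within the scatter) in this assay and is the first measured change on the five-membered aromatic ring with 1 sulfur. It shows that, at this carbon next to the ring atom that bears a large group, thiophen-2-yl to 3-methylthiophen-2-yl leaves the number within the scatter.

The compounds shown leave open whether an ethyl group, a methoxy group or a chlorine atom on the same carbon would also leave the number within the scatter, and whether a methyl group on another carbon of this ring would do so. They also leave open how this methyl group would read on the opposite double-bond configuration, that of compound 3. What is known about these compounds offers no explanation for the result with the methyl group.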